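The source may report more compounds than this note shows. Statements on the series, on what has been measured and on what is new or still open speak of the compounds shown alone.

In a functional assay on the whole organism (Hindlimb, strain albino) with Mus musculus as the target, in the maximal electroshock model, with a stated time of 0.5 h (on this read-out higher numbers stand for an effect only at larger amounts of compound and lower numbers for an effect already at smaller amounts), compound 3 (`COc1ccc(/C=C/C(=O)Nc2nc3ccc(Cl)cc3s2)cc1`) gives 259 umol/kg, and compound 1 (`COc1ccc(/C=C/C(=O)Nc2nc3ccc([N+](=O)[O-])cc3s2)cc1`) gives 315 umol/kg, within the scatter of it. Compound 2 (`O=C(/C=C/c1ccccc1)Nc1nc2ccccc2s1`) gives 646 umol/kg, a higher number than compound 3 and beyond the scatter.

Next in the series is compound 4 (`COc1ccc(/C=C/C(=O)Nc2nc3ccccc3s2)cc1`), with hydrogen in place of chloro on an aromatic carbon. Among the measured compounds shown here, the one measured step at this place is a 1.2-fold lower number from compound 1 to compound 3 (0.09 log units; within the scatter), chloro in place of nitro on an aromatic carbon, and it does not separate those two groups. For the measured compounds named here, no measured step leads to hydrogen there. Compound 2 also has hydrogen at that place but lacks the methoxy group as well, so it is only a loose guide. With compound 2 at 646 umol/kg, a modest step to a higher number is expected in this assay, possibly no larger than the scatter. The estimated step is a 1.6-fold higher number from compound 3 to compound 4 (0.21 log units; within the scatter). For compound 4 the expected value is 420 umol/kg, with an estimated range of 230 umol/kg to 760 umol/kg.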

Compound 4, dose for half-maximal effect: 435 umol/kg
Estimate against measurement, compound 4: 1.0-fold (0.02 log units) below, within the range that was stated.
By their numbers in this assay, from the lowest: compounds 3, 1, 4 and 2 (each within the scatter of the next, the first and the last beyond it).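

In this assay both a 1.7-fold higher number from compound 3 to compound 4 (0.23 log units; within the scatter) and a 1.4-fold higher number from compound 1 to compound 4 (0.14 log units; within the scatter) lie within the scatter, so hydrogen, chloro and nitro on this aromatic carbon are not separated. Among the compounds shown here, this is the first reading of hydrogen at this place, and it extends the earlier comparison of chloro with nitro to a third group without opening a gap beyond the scatter. The methoxy group also gets its first one-place reading: a 1.5-fold lower number from compound 2 to compound 4 (0.17 log units; within the scatter) is again within the scatter, so neither place has yet shown a step beyond it.

On these data alone, whether an amine or a carboxylic acid on this aromatic carbon would give a step beyond the scatter stays open, as does the outcome of a longer chain in place of methoxy. Nothing measured here speaks to what lies behind the size of these steps.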